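The source may report more compounds than this note shows. Statements on the series, on what has been measured and on what is new or still open speak of the compounds shown alone.

Series notes. Within the data shown here, compound 1 `CCCn1c(=O)n(CC(=O)O)c(=O)c2[nH]cnc21` is the first of three measured members; in an assay on Cerebral cortex for binding affinity to adenosine receptor A1 (Cavia porcellus), read by radioligand binding (on this read-out higher numbers stand for weaker inhibition and lower numbers for stronger inhibition), compound 1 reaches only the limit > 200000 nM. Among the measured compounds shown here, compound 2 `C=CCCn1cnc2c1c(=O)n(C)c(=O)n2CCC` gives 6000 nM in this assay and is the only member with a numbered value. Compound 3 `CCCn1c(=O)n(C)c(=O)c2c1ncn2CC(N)=O` carries the carbamoylmethyl chain; in this assay compound 3 again stops at the limit > 200000 nM. For the measured compounds named here, the single measured step, an at least 33-fold higher number from compound 2 to compound 3 (1.52 log units; beyond the scatter), runs into (the limit of > 200000 nM in this assay, at which 2 of the 3 values shown sit), so its true size is known only as a bound. Compound 3 therefore stands at the weak end of what has been seen, beside compound 1.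

Compound 4 `CCCn1c(=O)n(C)c(=O)c2c1ncn2CCN(C)C` differs from compound 3 by (dimethylamino)methyl in place of carbamoyl on a saturated chain carbon bound to an aromatic nitrogen. Going by the values given here, the only step bearing on this place is an at least 33-fold higher number from compound 2 to compound 3 (1.52 log units; beyond the scatter), which shows the carbamoyl arm faring far worse than allyl; taking the carbamoyl away is thus expected to move the number downward, though the entering chain has no measured counterpart in the set and the starting point is itself a limit. For compound 4 in this assay the expected value is 50000 nM, between 8000 nM and 200000 nM, an expected step of an at least 4.0-fold lower number from compound 3 to compound 4 (0.60 log units; beyond the scatter).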

Compound 4, inhibition constant: > 200000 nM
Compound 4: only a limit was reported; the forecaster's own chance of this, stated with the estimate: 40%; middle value at least 4.0-fold (0.60 log units) from the limit.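

Replacing the vinyl end of the chain on this aromatic nitrogen with dimethylamino gives an at least 33-fold higher number from compound 2 to compound 4 (1.52 log units; beyond the scatter), so the large loss seen for the carbamoylmethyl chain is not confined to that one group. The change from carbamoyl to (dimethylamino)methyl removes the hydrogen-bond donor of the carbamoyl, yet in this assay compound 4 still yields only a limit and no numbered value. The step between compound 3 and compound 4 cannot be read, because both results are limits: the limit of > 200000 nM in this assay, at which 3 of the 4 values shown sit.

On these data alone, how far compound 3 and compound 4 lie beyond that limit remains open, so the two chains cannot be ranked. Also open, as far as these compounds go, is whether a saturated butyl chain, a methoxyethyl chain or a longer amine chain at this place would keep a numbered value, as compound 2 does with its 6000 nM reading.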